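From butyl to 3-methoxypropyl on the shared core

The source may hold more compounds than are shown below. What is called first, only, known or untested is meant among the compounds shown, and "the series" means these compounds.

In a functional assay on RAW264.7 cells (Mus musculus) for inhibition, read by Griess assay, with stated times of 1 h and 24 h (a lower number here means a stronger inhibitor, a higher number a weaker inhibitor), compound 1 `COc1cc(OC)c2c(c1)C(C(O)c1ccc(O)cc1)OC2=O` gives > 10000 nM, a limit of the assay. Compound 2 `COc1ccc(C(O)C2OC(=O)c3c(OC)cc(OC)cc32)cc1` gives > 10000 nM, also a limit. Among the compounds with values here, compound 3 `CCCCOc1ccc(C(O)C2OC(=O)c3c(OC)cc(OC)cc32)cc1` gives 1800 nM, the only actual number so far. Compound 4 `COCCCOc1ccc(C(O)C2OC(=O)c3c(OC)cc(OC)cc32)cc1` differs from it by methoxy in place of methyl on a saturated chain carbon, three bonds along the chain from an oxygen on an aromatic ring: butyl becomes 3-methoxypropyl. The closest evidence concerns the chain itself: an at least 5.5-fold lower number from compound 2 to compound 3 (0.74 log units; beyond the scatter), and likewise an at least 5.5-fold lower number from compound 1 to compound 3 (0.74 log units; beyond the scatter), whereas a step that the two limits leave unreadable from compound 1 to compound 2. Neither readable step tests a methoxy group, so the chain of compound 3 may tolerate the change only partly. A modest move towards a higher number in this assay is therefore expected, and the expected step is a 1.9-fold higher number from compound 3 to compound 4 (0.29 log units; within the scatter). Compound 4 is estimated at 3500 nM, with an expected range of 1200 nM to 10000 nM.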

Compound 4, half-maximal inhibitory concentration: 1260 nM
For compound 4 the middle estimate is 2.8-fold (0.44 log units) above the measured one; the measured number falls inside the stated range.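

In this assay, methoxy in place of methyl on a saturated chain carbon, three bonds along the chain from an oxygen on an aromatic ring, is tolerated, with a 1.4-fold lower number from compound 3 to compound 4 (0.15 log units; within the scatter). The readable activity therefore does not rest on butyl alone, since 3-methoxypropyl gives an at least 7.9-fold lower number from compound 2 to compound 4 (0.89 log units; beyond the scatter) and an at least 7.9-fold lower number from compound 1 to compound 4 (0.89 log units; beyond the scatter). Both of these steps start from a limit of the assay: the limit of > 10000 nM in this assay, at which 2 of the 4 values shown sit.

From the compounds shown here alone, whether an amine, a carboxylic acid or a longer chain at this place would preserve this activity remains open.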